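The source may report more compounds than this note shows. Statements on the series, on what has been measured and on what is new or still open speak of the compounds shown alone.

Compound 1 `COc1ccc(C2=C(c3cc(OC)c(OC)c(OC)c3)C(=O)CC2O[SiH2]C(C)(C)C)cc1` gives no exact number in an ADME assay on L132 cells (Homo sapiens) for cytotoxicity, read by MTT assay, with a stated time of 72 h; a higher number here means a weaker inhibitor, a lower number a stronger inhibitor. In this assay compound 1 gives > 100 ug/mL, which is a limit and not a number. Compound 2 `COc1cc(C2=C(c3ccccc3)C(O[SiH2]C(C)(C)C)CC2=O)cc(OC)c1OC` gives > 100 ug/mL, which is also a limit. The two measured compounds therefore stand together at the limit of > 100 ug/mL in this assay, at which 2 of the 2 values shown sit. For the measured compounds named here, the only measured step is a step that the two limits leave unreadable from compound 1 to compound 2, so it offers no size to borrow, and it concerns a change elsewhere in the molecule.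

Compound 3 `COc1ccc(C2=C(c3cc(OC)c(OC)c(OC)c3)C(=O)CC2O)cc1` differs from compound 1 in one place: a hydrogen atom in place of a group of 5 heavy atoms (4 carbon, 1 silicon; no ring), on an oxygen on a saturated carbon. The group comes off an oxygen on a saturated carbon, and a hydrogen atom takes its place. Going by the values given here, no measured step covers this change, so the numbers point in no direction, and any expectation for it is loose. The expectation rests on compound 1, whose > 100 ug/mL is a limit. In this assay the expected step, a rough one, is a number no higher from compound 1 to compound 3 (the limit leaves the size open). For compound 3 the estimated value is 100 ug/mL, with an expected range from 20 ug/mL to 200 ug/mL.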

Compound 3, half-maximal inhibitory concentration: 10 ug/mL
Estimate against measurement, compound 3: 10-fold (1.00 log units) above; measured number below the stated range.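

Exchanging the group of 5 heavy atoms (4 carbon, 1 silicon; no ring) for a hydrogen atom, on an oxygen on a saturated carbon, gives in this assay an at least 10-fold lower number from compound 1 to compound 3 (1.00 log units; beyond the scatter). A lower number here means a stronger inhibitor, so this oxygen is the first place among the compounds shown where a change in structure has a readable effect on the cells. Compound 3 is also the only compound shown to come away from the limit that holds the other two: the limit of > 100 ug/mL in this assay, at which 2 of the 3 values shown sit.

Only this one replacement on the oxygen is shown, so it stays open whether a methyl group, an acetyl group or a longer chain there would keep the number of compound 3 or return to a limit like that of compound 1. On these data alone, it also stays open whether the same exchange on compound 2 would give a similar step, and what the methoxy group that separates compound 1 from compound 2 contributes, as the step between those two cannot be read.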